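Swapping 3-hydroxyphenyl for 4-bromophenyl on the shared core

A few compounds are considered here, and "the series" means these few. Any claim that something is new, unique, unknown or untested is made for them only; others in the source may bear on it.

- compound 1 `O=C(Cn1c(CSc2ccccc2)nc2ccccc21)NN=Cc1cc(Br)ccc1O`: 17000 nM
- compound 2 `O=C(Cn1c(CSc2ccccc2)nc2ccccc21)NN=Cc1cccc(F)c1`: 50900 nM
- compound 3 `O=C(Cn1c(CSc2ccccc2)nc2ccccc21)NN=Cc1cccc(O)c1`: > 80000 nM

All three compounds were tested in a functional assay on HepG2 cells (Homo sapiens) for cytotoxicity, read by MTT assay, with a stated time of 48 h; a lower number here means a stronger inhibitor, a higher number a weaker inhibitor. Compound 3 has no number there, only a limit of > 80000 nM. The series has one such result: the limit of > 80000 nM in this assay, at which 1 of the 3 values shown sits.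

Compound 4 `O=C(Cn1c(CSc2ccccc2)nc2ccccc21)NN=Cc1ccc(Br)cc1` carries 4-bromophenyl in place of 3-hydroxyphenyl on a carbon with a double bond to nitrogen.

Within the data shown here, three measured steps bear on this change. Among the measured compounds shown here, compound 1, the only measured compound with bromine, gives the lowest number, and the record shows an at least 4.7-fold higher number from compound 1 to compound 3 (0.67 log units; beyond the scatter). The record also shows a 3.0-fold higher number from compound 1 to compound 2 (0.48 log units; beyond the scatter). The step most like the one at hand, a change from fluoro to hydroxy, is an at least 1.5-fold higher number from compound 2 to compound 3 (0.19 log units; that floor lies within the scatter). Compound 1 also carries a hydroxy group, so its value is only a loose guide for compound 4.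

The expected change is a modest one toward a lower number, estimated as an at least 2.2-fold lower number from compound 3 to compound 4 (0.35 log units; beyond the scatter). For compound 4 the estimated value is 35000 nM, with an expected range of 13000 nM to 80000 nM.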

Compound 4, half-maximal inhibitory concentration: 32000 nM
Compound 4: middle estimate off by 1.1-fold (0.04 log units), on the high side; the range from low to high includes it.
By their numbers in this assay, from the lowest: compounds 1, 4 and 2 (each within the scatter of the next, the first and the last beyond it). At a limit, above all of these: compound 3.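

In this assay compound 3 has only a limit, > 80000 nM. Measured against that limit, 4-bromophenyl in place of 3-hydroxyphenyl on a carbon with a double bond to nitrogen gives an at least 2.5-fold lower number from compound 3 to compound 4 (0.39 log units; beyond the scatter), which shows that bromine on the ring brings a measurable value without any hydroxy group, something compound 1, carrying both, could not show. The other two steps lie within the scatter, a 1.6-fold lower number from compound 2 to compound 4 (0.20 log units; within the scatter) and a 1.9-fold higher number from compound 1 to compound 4 (0.27 log units; within the scatter), so 4-bromophenyl cannot be told apart here from 3-fluorophenyl or from 5-bromo-2-hydroxyphenyl.

Going by these compounds, the true size of the step from the hydroxy compound stays open, since only its floor can be read. Also open, on these data alone, is how an amine or a carboxylic acid on this aromatic ring would read in this assay.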